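The source may report more compounds than this note shows. Statements on the series, on what has been measured and on what is new or still open speak of the compounds shown alone.

Of the compounds shown here, two with a shared core have been tested so far in a functional assay on BGC-823 cells (Homo sapiens) for cytotoxicity, read by MTT assay; a higher number here means a weaker inhibitor, a lower number a stronger inhibitor. Compound 1 (`Cc1c(O)cc(CCCC(C)C)oc1=O`) gives > 200000 nM, which is a limit of the assay and not a number. Compound 2 (`Cc1c(O)cc(CCCCC(C)(C)O)oc1=O`) gives > 200000 nM, which is again only a limit. Within the data shown here, compound 2 therefore has no number of its own, and the whole series so far stands at the limit of > 200000 nM in this assay, at which 2 of the 2 values shown sit.

The next compound, compound 3 (`CCC(C)CCCCc1cc(O)c(C)c(=O)o1`), differs from compound 2 by one change: sec-butyl in place of 1-hydroxy-1-methylethyl on a saturated chain carbon, four bonds along the chain from an aromatic carbon. Among the measured compounds shown here, the single measured step that bears on this change, a step that the two limits leave unreadable from compound 1 to compound 2, also alters the end of the chain, but it gives no size to carry over. With both ends of that step at the limit, nothing in the data points in either direction. No step beyond the scatter is expected in this assay, and a further reading at the limit is the likeliest outcome. The expected move is a step that the limit leaves unreadable from compound 2 to compound 3. Compound 3 is estimated at 250000 nM, with an expected range from 80000 nM to 600000 nM.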

Compound 3, half-maximal inhibitory concentration: > 200000 nM
Compound 3: a limit, no number (the forecaster's own chance of this, stated with the estimate: 75%); the middle value is on the limit's open side.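

No new step can be read: the steps linking compound 3 with compound 1 and compound 2 all end at limits of the assay, so none has a size. The series now stands as follows: the limit of > 200000 nM in this assay, at which 3 of the 3 values shown sit. The compounds shown leave open what change on the shared core, if any, would give a measurable value in this assay.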